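This account rests on a few compounds, and the source may have more. Where it says the series, first, only, none or still open, it means among the compounds named here.

- compound 1 `CC(CCO)n1cnc2c(Cl)nc(F)nc21` gives 19800 nM
- compound 2 `CCCC(CCO)n1cnc2c(Cl)nc(F)nc21` gives 16500 nM
- compound 3 `CCCCCC(CCO)n1cnc2c(Cl)nc(F)nc21` gives 8660 nM

These values come from a functional assay on HCT-116 cells (Homo sapiens) for antiproliferative activity, read by MTT assay, with a stated time of 48 h (a higher number here means a weaker inhibitor, a lower number a stronger inhibitor), and the three compounds share one core. They differ only in the saturated chain, where an ethyl or butyl group takes the place of a hydrogen. Compound 3 separates from only one of the other two, with a 2.3-fold lower number from compound 1 to compound 3 (0.36 log units; beyond the scatter) as a modest change. By contrast, a 1.9-fold lower number from compound 2 to compound 3 (0.28 log units; within the scatter) leaves that pair unresolved, and a 1.2-fold lower number from compound 1 to compound 2 (0.08 log units; within the scatter) does the same for the remaining pair.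

Compound 4 `CCCCCC(CCO)n1cnc2c(Cl)nc(Cl)nc21` keeps the chain of compound 3 and changes the core instead. The change is chloro in place of fluoro on an aromatic carbon, between two ring nitrogen atoms (chloro in place of fluoro on an aromatic carbon). Going by the values given here, no measured step involves this position, so the data give no direct guide to its direction. The chain steps show only how large changes have been in this small series, and even the largest, a 2.3-fold lower number from compound 1 to compound 3 (0.36 log units; beyond the scatter), is modest. No shift beyond the scatter is therefore expected in this assay for this single-atom exchange. The estimate corresponds to a 1.1-fold lower number from compound 3 to compound 4 (0.03 log units; within the scatter) as the expected step. Compound 4 is expected at 8000 nM with 3500 nM to 18000 nM as the estimated range.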

Compound 4, half-maximal inhibitory concentration: 6170 nM
Beside the measured number, compound 4's estimate is 1.3-fold (0.11 log units) above it, and the stated range covers the measured number.
By their numbers in this assay, from the lowest: compounds 4, 3, 2 and 1 (each within the scatter of the next, the first and the last beyond it).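

Going by these compounds alone, compound 4 gives the first reading at this position, the aromatic carbon between two ring nitrogen atoms, and in this assay the exchange of fluoro for chloro gives a 1.4-fold lower number from compound 3 to compound 4 (0.15 log units; within the scatter). The position therefore accepts chloro in place of fluoro with no shift that can be told apart from the ordinary variation between repeated measurements, so compound 3 and compound 4 cannot be placed in an order, and this single pair cannot show whether the change has any real effect on the cells. Nothing available here bears on this result or offers an explanation for it.

Going by these compounds, only fluoro and chloro appear at this carbon, so it remains open how an amine, a methoxy group or a plain hydrogen there would read in this assay. Also open is whether the chain steps seen with fluoro on the core carry over with chloro, since the chain of compound 3 and compound 4 is the only one shown with both groups.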